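The source may report more compounds than this note shows. Statements on the series, on what has been measured and on what is new or still open speak of the compounds shown alone.

Measured so far in an ADME assay on HepG2 2.2.15 cells (Homo sapiens) for cytotoxicity; on this read-out higher numbers stand for lower toxicity in this test and lower numbers for higher toxicity in this test:

Compound 1, `CCC(=O)OCCc1c(-c2ccccc2Cl)c2cc(Cl)ccc2[nH]c1=O`: compound 1 gives 95000 nM.
Compound 2, `O=C(O)CCCC(=O)OCCc1c(-c2ccccc2Cl)c2cc(Cl)ccc2[nH]c1=O`: compound 2 gives 110000 nM.
Compound 3, `O=C(CCC1CCCCC1)OCCc1c(-c2ccccc2Cl)c2cc(Cl)ccc2[nH]c1=O`: compound 3 gives 160000 nM.

Compound 3 has the highest of the three numbers, but only narrowly: the step of a 1.7-fold higher number from compound 1 to compound 3 (0.23 log units; within the scatter) and the step of a 1.5-fold higher number from compound 2 to compound 3 (0.16 log units; within the scatter) both lie within the scatter, as does a 1.2-fold higher number from compound 1 to compound 2 (0.06 log units; within the scatter). All three measured steps change the group on a saturated chain carbon two bonds along the chain from a carbonyl carbon, and none of them moved the number beyond the scatter.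

Compound 4, `O=C(COc1ccccc1)OCCc1c(-c2ccccc2Cl)c2cc(Cl)ccc2[nH]c1=O`, differs from compound 3 by phenoxy in place of cyclohexylmethyl on a saturated chain carbon bound to a carbonyl carbon. Within the data shown here, this change sits one bond closer to the carbonyl than the changes measured so far, and it brings in an aromatic ring and a hydrogen-bond acceptor, for which no measured step gives guidance. Among the measured compounds shown here, since every step so far has stayed within the scatter, the step from compound 3 to compound 4 is expected to be a 1.2-fold lower number from compound 3 to compound 4 (0.09 log units; within the scatter). Compound 4 is therefore estimated at 130000 nM, with a range from 60000 nM to 280000 nM.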

Compound 4, half-maximal cytotoxic concentration: 81000 nM
The estimate for compound 4 lay 1.6-fold (0.21 log units) above the measured number, and the stated range covers the measured number.
By their numbers in this assay, from the lowest: compounds 4, 1, 2 and 3 (each within the scatter of the next).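

In this assay, phenoxy on a saturated chain carbon bound to a carbonyl carbon gives a 2.0-fold lower number from compound 3 to compound 4 (0.30 log units; within the scatter), a 1.4-fold lower number from compound 2 to compound 4 (0.13 log units; within the scatter) and a 1.2-fold lower number from compound 1 to compound 4 (0.07 log units; within the scatter). The earlier steps shown here changed only saturated groups or a carboxylic acid chain, whereas compound 4 carries a six-membered aromatic ring and a hydrogen-bond acceptor, and its number still stays within the scatter of all three others. So across these four compounds, this part of the ester side chain accepts quite different groups without a clear change in the read-out, though no information is available to explain the numbers.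

An amine or an amide on this carbon remains an open case, as does a phenoxy ring carrying a chlorine. On these data alone, all four compounds also share one core, so the effect of changes to that core remains open too.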